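Adding a Methyl to the Acid Side Chain of Compound 1

This account rests on a few compounds, and the source may have more. Where it says the series, first, only, none or still open, it means among the compounds named here.

Measured compounds:
compound 1, `O=C(O)Cn1nc(Cn2cc3cc(OCC4CC4)c(Cl)cc3n2)c2ccccc2c1=O`: 11 nM
compound 2, `O=C(O)Cn1nc(CC(=O)Nc2ccc(OC(F)(F)F)c(Cl)c2)c2ccccc2c1=O`: 389 nM

In a functional assay on CHO cells for antagonist activity at sphingosine 1-phosphate receptor 2 (Homo sapiens), read by calcium flux (a higher number here means a weaker inhibitor, a lower number a stronger inhibitor), compound 1 gives 11 nM, the lowest of the two numbers recorded. Compound 2 gives 389 nM in this assay, and the gap between the two values lies well beyond the usual scatter; the two structures differ in several places at once, so nothing more is read from that pair.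

Compound 3, `C[C@H](C(=O)O)n1nc(Cn2cc3cc(OCC4CC4)c(Cl)cc3n2)c2ccccc2c1=O`, is not yet measured. It differs from compound 1 in one place: methyl in place of hydrogen on a saturated chain carbon bound to an aromatic nitrogen and a carbonyl carbon. Going by the values given here, no pair of measured compounds shows what such a single methyl does here, so the expectation rests on the size of the change alone. Compound 3 is expected to stay close to compound 1 in this assay, with the step of a 1.1-fold higher number from compound 1 to compound 3 (0.04 log units; within the scatter) not clearly beyond the scatter in either direction. Compound 3 is therefore estimated at 12 nM, with a range from 3 nM to 50 nM.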

Compound 3, half-maximal inhibitory concentration: 3.2 nM
For compound 3 the middle estimate is 3.8-fold (0.57 log units) above the measured one; the measured number falls inside the stated range.
By their numbers in this assay, from the lowest: compound 3; then compound 1; then compound 2.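

Going by these compounds alone, the change from carboxymethyl to 1-carboxyethyl brings a 3.4-fold lower number from compound 1 to compound 3 (0.54 log units; beyond the scatter) in this assay and is the first step in this set that changes one place only. It shows that the saturated chain carbon bound to an aromatic nitrogen and a carbonyl carbon accepts a methyl in place of hydrogen, and that this single added carbon lowers the number by a modest amount rather than leaving it unchanged. No evidence at hand bears on why the number falls.

Going by these compounds, it remains open whether an ethyl group, a second methyl or the opposite configuration at this carbon would lower the number further or raise it. On these data alone, it is also open whether the same methyl would have a similar effect on the acid side chain of compound 2.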